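An ether-bearing chain replaces the cyclopropyl of compound 2

A few compounds are considered here, and "the series" means these few. Any claim that something is new, unique, unknown or untested is made for them only; others in the source may bear on it.

Of the compounds shown here, two sharing the same core have been measured in an assay on cells with melanin-concentrating hormone receptor 1 (Homo sapiens) as the target, read by radioligand binding; on this read-out lower numbers stand for stronger inhibition and higher numbers for weaker inhibition. Compound 1 `CC(C)OCCOc1cccc2ccc(N)nc12` reaches only the limit of the assay, giving > 2000 nM in this assay. Within the data shown here, compound 2 `Nc1ccc2cccc(OCCC3CC3)c2n1` gives 492 nM in this assay, the only true number among the two results. Among the measured compounds shown here, the single step in this assay, an at least 4.0-fold lower number from compound 1 to compound 2 (0.60 log units; beyond the scatter), is one of the measured steps, and it passes through the limit of > 2000 nM in this assay, at which 1 of the 2 values shown sits, at one end.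

Compound 3 `COC(C)(C)CCOc1cccc2ccc(N)nc12` differs from compound 2 by 1-methoxy-1-methylethyl in place of cyclopropyl on a saturated chain carbon, two bonds along the chain from an oxygen on an aromatic ring. That change brings an oxygen back into the chain near where compound 1 carried its isopropoxy, and compound 1 sat at the limit in this assay, so the step is expected to run in the opposite direction from the measured one; the estimated step is a 3.0-fold higher number from compound 2 to compound 3 (0.48 log units; beyond the scatter). Compound 3 is therefore expected to give about 1500 nM in this assay, with a range from 500 nM to 5000 nM.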

Compound 3, half-maximal inhibitory concentration: 132 nM
Beside the measured number, compound 3's estimate is 11-fold (1.06 log units) above it; the whole stated range lies above it.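

With 1-methoxy-1-methylethyl on the saturated chain carbon, this assay shows a 3.7-fold lower number from compound 2 to compound 3 (0.57 log units; beyond the scatter), so a group carrying an oxygen at this place need not fall behind cyclopropyl. Compound 1 also carries an oxygen in its chain, and its > 2000 nM is a limit of the assay, not a number. The two oxygen-bearing groups still lie far apart, with an at least 15-fold lower number from compound 1 to compound 3 (1.18 log units; beyond the scatter), so the presence of an oxygen alone does not settle the result at this place.

The compounds shown leave open whether the gain follows the methoxy oxygen or the branched carbon, which a tert-butyl group at the same place would help to separate. As far as these compounds go, how a hydroxyl or an amine in place of the methoxy would read also remains open.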